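Capping a Phenol: From Compound 2 to Compound 3

The source may hold more compounds than are shown below. What is called first, only, known or untested is meant among the compounds shown, and "the series" means these compounds.

Compound 1 `COc1cc(Cl)cc(-c2nn(-c3cccc(NC(=O)c4cccc(C(F)(F)F)c4)c3)cc2-c2ccncc2)c1` and compound 2 `O=C(Nc1cccc(-n2cc(-c3ccncc3)c(-c3cc(O)cc(Cl)c3)n2)c1)c1cc(C(F)(F)F)cc(C(F)(F)F)c1` share a core and were both tested in a functional assay on SK-OV-3 cells (Homo sapiens) for inhibition, read by sulforhodamine B assay, with a stated time of 48 h, tested at 10 uM; on this read-out higher numbers stand for a weaker effect at the one concentration tested and lower numbers for a stronger effect. In this assay compound 1 gives 81.6%, while compound 2 gives 68.9%, the lower of the two numbers and a gap beyond the scatter. Compound 3 `COc1cc(Cl)cc(-c2nn(-c3cccc(NC(=O)c4cc(C(F)(F)F)cc(C(F)(F)F)c4)c3)cc2-c2ccncc2)c1` differs from compound 2 by methyl in place of hydrogen on an oxygen on an aromatic ring, hydroxy to methoxy. Among the measured compounds shown here, no single-change step between measured compounds exists, so the direction of this change in this assay is untested. For compound 3 the expected step is a number 5.1 percentage points higher from compound 2 to compound 3 (within the scatter), of uncertain direction and likely within the scatter. Compound 3 is therefore estimated at 74%, with a range from 56% to 92%.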

Compound 3, a percentage reported as activity, at one concentration (the size of the read-out at that concentration, not a potency): 83.4%
Compound 3: middle estimate off by 9.4 percentage points, on the low side, and the stated range covers the measured number.
By their numbers in this assay, from the lowest: compound 2; then compounds 1 and 3 (each within the scatter of the next).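

Among the compounds shown here, the first single-change comparison at this oxygen gives a direction in this assay: hydroxy to methoxy yields a number 14.5 percentage points higher from compound 2 to compound 3 (beyond the scatter), so the free hydroxy goes with the stronger effect at this one concentration. With methoxy kept, trifluoromethyl in place of hydrogen on an aromatic carbon yields a number 1.8 percentage points higher from compound 1 to compound 3 (within the scatter), so that change makes no difference that can be read here. Nothing measured here explains the hydroxy step. Going by these compounds, it remains open whether the trifluoromethyl step would read the same with hydroxy kept, and whether an ethoxy group or an amine at this place would track methoxy or hydroxy.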